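The source may report more compounds than this note shows. Statements on the series, on what has been measured and on what is new or still open speak of the compounds shown alone.

Measured compounds:
compound 1 `CC(C)C[C@H](N)c1cc(Cl)ccc1N1CCN(C(=O)C(C)Cc2ccc(Cl)cc2)CC1`: 67 nM
compound 2 `COc1cc(Cl)ccc1C[C@@H](C)C(=O)N1CCN(c2ccc(C)cc2[C@@H](N)CC(C)C)CC1`: 8.1 nM
compound 3 `CC(C)C[C@H](N)c1cc(C(F)(F)F)ccc1N1CCN(C(=O)COc2cccc(Cl)c2Cl)CC1`: 2500 nM

In an assay on HEK293 cells for displacement of a labelled ligand from Melanocortin receptor 4 (Homo sapiens) (a lower number here means a stronger inhibitor, a higher number a weaker inhibitor), compound 3 gives the highest number of the three, and its gaps to compound 1 and to compound 2 are both well beyond the scatter. Compound 4 `Cc1ccc(CC(C)C(=O)N2CCN(c3ccc(C(F)(F)F)cc3[C@@H](N)CC(C)C)CC2)cc1C` is not yet measured. It differs from compound 3 in one place: 1-(3,4-dimethylbenzyl)ethyl in place of (2,3-dichlorophenoxy)methyl on a carbonyl carbon. Going by the values given here, no measured pair isolates this change, so its size is not known directly. The amide side of compound 4 resembles that of compound 1 and compound 2 more than that of compound 3, so a large step downward in this assay, well beyond the scatter, is expected: a 63-fold lower number from compound 3 to compound 4 (1.80 log units; beyond the scatter). For compound 4 the expected value is 40 nM, within 8 nM to 200 nM.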

Compound 4, inhibition constant: 240 nM
Estimate against measurement, compound 4: 6.0-fold (0.78 log units) below; measured number above the stated range.
By their numbers in this assay, from the lowest: compound 2; then compound 1; then compound 4; then compound 3.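

On the carbonyl carbon, 1-(3,4-dimethylbenzyl)ethyl in place of (2,3-dichlorophenoxy)methyl gives a 10-fold lower number from compound 3 to compound 4 (1.02 log units; beyond the scatter) in this assay, so this position alone moves the number beyond the scatter while the rest of compound 3 stays fixed. The entering group has no hydrogen-bond acceptor and the leaving group has one, while each keeps one six-membered aromatic ring of carbon only. No available measurement accounts for the step.

Which part of the exchange carries the step remains open, as the oxygen, the chlorines and the methyl groups all change together. Also open, on these data alone, is how an amine or a carboxylic acid would read at this place.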